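Truncating the amide of compound 1 to give compound 4

A few compounds are considered here, and "the series" means these few. Any claim that something is new, unique, unknown or untested is made for them only; others in the source may bear on it.

Working notes on the series. Compound 1 `COc1ccc(-c2cnc(NC(=O)c3ccc(Br)cc3)n2C)cc1` stands only at a limit: in a toxicity assay on THP-1 cells (Homo sapiens) for inhibition (a higher number here means that more compound is tolerated, a lower number that less compound is tolerated), compound 1 gives > 100000 nM, which is a limit of the assay and not a number. Compound 2 `COc1ccc2c(c1)nc(NC(=O)c1ccc(F)cc1)n2C` likewise gives > 100000 nM, a limit. Compound 3 `Cn1c(-c2ccccc2)cnc1NC(=O)c1ccc(Br)cc1` gives > 100000 nM, again a limit. Within the data shown here, the one step between measured compounds, a step that the two limits leave unreadable from compound 1 to compound 3, is therefore not readable in size, because of the limit of > 100000 nM in this assay, at which 3 of the 3 values shown sit. Compound 4 `COc1ccc(-c2cnc(NC(C)=O)n2C)cc1` differs from compound 1 by methyl in place of 4-bromophenyl on a carbonyl carbon. Among the measured compounds shown here, no measured step bears on this change, and nothing in the three values points away from the limit. Compound 4 is therefore expected to give 150000 nM, within 60000 nM to 400000 nM, and the step that the limit leaves unreadable from compound 1 to compound 4 is expected to be none beyond the scatter.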

Compound 4, half-maximal cytotoxic concentration: > 100000 nM
Compound 4: a limit, no number; the forecaster's own chance of this, stated with the estimate: 85%; the middle value lies beyond the limit too.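

The step from compound 1 to compound 4 cannot be read, since in this assay both stand only at a limit and not at a number: the limit of > 100000 nM in this assay, at which 4 of the 4 values shown sit.

The compounds shown leave open what change to the shared core, if any, would bring a number within range in this assay and not a limit.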